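From phenyl to 4-fluorophenyl on a shared core

The source may hold more compounds than are shown below. What is called first, only, known or untested is meant among the compounds shown, and "the series" means these compounds.

Compound 1 `CNC(=O)c1cc(Oc2ccc(NC(=O)c3cc(-c4ccc(Cl)cc4)ncn3)cc2)ccn1` gives > 100000 nM (a limit of the assay)
Compound 2 `CNC(=O)c1cc(Oc2ccc(NC(=O)c3cc(-c4ccccc4)ncn3)cc2)ccn1` gives 44200 nM

Both compounds were tested in a functional assay on PC-3 cells (Homo sapiens) for cytotoxicity, read by MTT assay, with a stated time of 72 h; on this read-out higher numbers stand for weaker inhibition and lower numbers for stronger inhibition. Compound 1 gives > 100000 nM there, which is a limit and not a number. Within the data shown here, compound 2 gives 44200 nM, the only true number in this small set.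

The next compound is compound 3 `CNC(=O)c1cc(Oc2ccc(NC(=O)c3cc(-c4ccc(F)cc4)ncn3)cc2)ccn1`, and the change from compound 2 is fluoro in place of hydrogen on an aromatic carbon. It places fluoro in place of hydrogen on an aromatic carbon, para to a large group.

Among the measured compounds shown here, one measured step bears on this change, hydrogen in place of chloro on an aromatic carbon, which gave an at least 2.2-fold lower number from compound 1 to compound 2 (0.35 log units; beyond the scatter). Its size is only a bound, since it rests on (the limit of > 100000 nM in this assay, at which 1 of the 2 values shown sits). Read in reverse, this step suggests that a halogen in place of that hydrogen raises the number, so a modest rise in this assay is expected, possibly none beyond the scatter. The expected change is a 1.4-fold higher number from compound 2 to compound 3 (0.13 log units; within the scatter). For compound 3 the estimate is 60000 nM, with an expected range from 25000 nM to 100000 nM.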

Compound 3, half-maximal inhibitory concentration: > 100000 nM
Compound 3: only a limit was reported; the forecaster's own chance of this, stated with the estimate: 25%; middle value at least 1.6-fold (0.22 log units) from the limit.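

With fluoro in place of hydrogen on this aromatic carbon, this assay shows an at least 2.2-fold higher number from compound 2 to compound 3 (0.35 log units; beyond the scatter) and so gives a second halogen case that moves the same way as chloro. Chloro and fluoro now agree at this position, so the loss no longer rests on a single substituent, and among the three compounds only compound 2, with its plain phenyl, gives a true number. The size of the new step is only a bound, and the step between compound 1 and compound 3 cannot be read, because both of their values are limits: the limit of > 100000 nM in this assay, at which 2 of the 3 values shown sit.

Going by these compounds, whether chloro and fluoro differ from each other in this assay remains open, since neither compound gives a true number there. Also open, on these data alone, is what a group that is not a halogen would do on this same carbon, such as methoxy, an amine or a carboxylic acid, and whether any such group would bring the number below that of compound 2.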